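From a Branched Alkyl to an Aryl Ether on the Core

A few compounds are considered here, and "the series" means these few. Any claim that something is new, unique, unknown or untested is made for them only; others in the source may bear on it.

Within the data shown here, compound 2 (`CCC(CC)c1ccc2c(NCCCNCc3ccco3)ccnc2c1`) stands lowest of the two numbers measured so far in a physicochemical assay for solubility, with a stated time of 18 h, at pH 7.4; on this read-out higher numbers stand for higher solubility and lower numbers for lower solubility: compound 2 gives 4200 nM, while compound 1 (`FC(F)(F)c1ccc(-c2ccc3c(NCCCNCc4ccco4)ccnc3c2)cc1`) gives 32000 nM. Among the measured compounds shown here, the one recorded step, a 7.6-fold lower number from compound 1 to compound 2 (0.88 log units; beyond the scatter), is the only precedent available. Compound 3 (`COc1ccccc1Oc1ccc2c(NCCCNCc3ccco3)ccnc2c1`) differs from compound 2 in one place: 2-methoxyphenoxy in place of pentan-3-yl on an aromatic carbon. The earlier step bears on this change only loosely, since the pentan-3-yl group leaves again and an aromatic ring enters in its place, now carried through an oxygen rather than attached directly. Because the move away from the aryl group in a 7.6-fold lower number from compound 1 to compound 2 (0.88 log units; beyond the scatter) lowered the number, the reverse direction is expected here: a moderate rise, estimated as a 6.0-fold higher number from compound 2 to compound 3 (0.77 log units; beyond the scatter), beyond the scatter. Compound 3 is therefore expected to give about 25000 nM in this assay, within a range from 8000 nM to 80000 nM.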

Compound 3, solubility: 14500 nM
Compound 3: the middle estimate sits 1.7-fold (0.24 log units) above what was measured; measured number inside the range.
By their numbers in this assay, from the lowest: compound 2; then compound 3; then compound 1.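

In this assay, 2-methoxyphenoxy in place of pentan-3-yl on this aromatic carbon gives a 3.5-fold higher number from compound 2 to compound 3 (0.54 log units; beyond the scatter), so a second group carrying an aromatic ring, here held through an oxygen, also stands above the branched alkyl group. The two ring-bearing groups do not match, however: 2-methoxyphenoxy in place of 4-(trifluoromethyl)phenyl gives a 2.2-fold lower number from compound 1 to compound 3 (0.34 log units; beyond the scatter), which places compound 3 between compound 2 and compound 1. Among these three compounds, then, the group at this position moves the number in both directions, and the kind of aromatic group matters as well as its presence.

On these data alone, whether the linking oxygen or the methoxy group sets compound 3 apart from compound 1 stays open, as does what a morpholine or a carboxylic acid would give at this carbon. No measurement at hand explains the order of these numbers.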